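Methyl to methoxy: from compound 3 to compound 4

The source may report more compounds than this note shows. Statements on the series, on what has been measured and on what is new or still open speak of the compounds shown alone.

In a functional assay on HCT-116 cells (Homo sapiens) for cytotoxicity, read by MTT assay, with a stated time of 72 h (on this read-out lower numbers stand for stronger inhibition and higher numbers for weaker inhibition), compound 3 `Cc1ccc(S(=O)(=O)c2nc3ccccc3nc2N2CCc3ccccc3C2)cc1` gives 39000 nM as the higher of the two true numbers in the series. Compound 2 `O=S(=O)(c1ccccc1)c1nc2ccccc2nc1N1CCc2ccccc2C1` gives 18700 nM in the same read-out. Compound 1 `COc1ccc(S(=O)(=O)c2nc3ccccc3nc2N2CCCC2)cc1` gives > 50000 nM as a limit of the assay and not a number.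

Compound 4 `COc1ccc(S(=O)(=O)c2nc3ccccc3nc2N2CCc3ccccc3C2)cc1` carries methoxy in place of methyl on an aromatic carbon, para to a large group, and the counted difference is methoxy in place of methyl on an aromatic carbon at this single place. Among the compounds with values here, the one measured step at this position is a 2.1-fold higher number from compound 2 to compound 3 (0.32 log units; beyond the scatter) for methyl in place of hydrogen, modest and only just beyond the scatter. Within the data shown here, no measured step covers methoxy itself, and compound 1 offers no matched comparison. Also relevant is the limit of > 50000 nM in this assay, at which 1 of the 3 values shown sits, as the ceiling of the read-out.

The expected change is a 1.1-fold lower number from compound 3 to compound 4 (0.05 log units; within the scatter) and thus no step beyond the scatter is anticipated. Compound 4 is estimated at 35000 nM with an expected range from 15000 nM to 50000 nM in this assay and a report as a limit remains possible.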

Compound 4, half-maximal inhibitory concentration: 22100 nM
The estimate for compound 4 lay 1.6-fold (0.20 log units) above the measured number, within the range that was stated.
By their numbers in this assay, from the lowest: compounds 2, 4 and 3 (each within the scatter of the next, the first and the last beyond it). At a limit, above all of these: compound 1.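

In this assay, methoxy at this place cannot be told apart from either of its neighbours: a 1.8-fold lower number from compound 3 to compound 4 (0.25 log units; within the scatter), and a 1.2-fold higher number from compound 2 to compound 4 (0.07 log units; within the scatter). The methyl step a 2.1-fold higher number from compound 2 to compound 3 (0.32 log units; beyond the scatter) is therefore not the start of a reading that carries over to methoxy, since compound 4 sits within the scatter of both compound 2 and compound 3. With the 4-methoxyphenyl group held, 1,2,3,4-tetrahydroisoquinolin-2-yl in place of pyrrolidin-1-yl gives an at least 2.2-fold lower number from compound 1 to compound 4 (0.35 log units; beyond the scatter), a step that has only a lower bound, as compound 1 stands at a limit and not a number: the limit of > 50000 nM in this assay, at which 1 of the 4 values shown sits.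

The compounds shown leave open whether a chlorine, a nitrile or a primary amine at this place would give a step beyond the scatter. They also leave open what the methoxy group does when paired with pyrrolidin-1-yl in a range where numbers can be read.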